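Fluorophenyl sulfone series: clearance notes for compound 3

The source may hold more compounds than are shown below. What is called first, only, known or untested is meant among the compounds shown, and "the series" means these compounds.

Two compounds of the shared core have numbers in an ADME assay on microsomes from liver (Homo sapiens) for metabolic stability, tested at 2.5 uM; on this read-out lower numbers stand for slow clearance and higher numbers for fast clearance. Compound 1 `COc1ccc(-c2c(S(=O)(=O)c3ccc(F)cc3)cnc3cc(F)ccc23)cc1` gives 1.77 mL/min in this assay. Compound 2 `O=S(=O)(c1cccc(F)c1)c1cnc2cc(F)ccc2c1-c1ccc(F)cc1` gives 0.11 mL/min in this assay, the lowest of the two numbers; compound 1 sits at a markedly higher number, beyond the scatter. Compound 1 and compound 2 differ in more than one place, so their gap is not tied to a single change.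

Compound 3 `O=S(=O)(c1ccc(F)cc1)c1cnc2cc(F)ccc2c1-c1ccc(F)cc1` has not been measured. The change from compound 2 is 4-fluorophenyl in place of 3-fluorophenyl on a sulfonyl sulfur.

Going by the values given here, no step between measured compounds isolates this change, so the size of the step from compound 2 to compound 3 is not anchored. The expectation is a step that stays within the scatter, with no direction claimed beyond it, because compound 2 gives 0.11 mL/min and the change leaves the rest of the structure intact. Compound 3 is expected to give 0.18 mL/min in this assay, with a range from 0.06 mL/min to 0.55 mL/min, a step of a 1.6-fold higher number from compound 2 to compound 3 (0.21 log units; within the scatter) that is estimated rather than measured.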

Compound 3, intrinsic clearance in a liver preparation (reported as CLH), per the amount of preparation that the assay uses: 1.34 mL/min
Estimate against measurement, compound 3: 7.4-fold (0.87 log units) below, outside the stated range (above it).
By their numbers in this assay, from the lowest: compound 2; then compounds 3 and 1 (each within the scatter of the next).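

Notes on the sulfonyl position: in this assay, 4-fluorophenyl in place of 3-fluorophenyl on a sulfonyl sulfur gives a 12-fold higher number from compound 2 to compound 3 (1.09 log units; beyond the scatter), so two groups with the same atoms are clearly separated at this place. With 4-fluorophenyl on the sulfonyl sulfur in both compounds, fluoro in place of methoxy on an aromatic carbon gives a 1.3-fold lower number from compound 1 to compound 3 (0.12 log units; within the scatter), which leaves the two within the scatter of each other, and the low number of compound 2 therefore tracks the 3-fluorophenyl in this set. Nothing at hand explains a step of this size at the sulfonyl position.

As far as these compounds go, whether the 3-fluorophenyl step carries over to a methoxy-bearing partner remains open. Also open, from the compounds shown here alone, is how a plain phenyl or a 4-chlorophenyl on the sulfonyl sulfur would read in this assay.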